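The source may hold more compounds than are shown below. What is called first, only, known or untested is meant among the compounds shown, and "the series" means these compounds.

Measured compounds:
Compound 1, `COc1cc(/C=C/C(=O)c2cccc(-n3cc(-c4ccc(Cl)cc4)[nH]c3=O)c2)ccc1O`: 8690 nM
Compound 2, `COc1ccc(-c2cn(-c3cccc(C(=O)/C=C/c4cc(OC)c(OC)c(OC)c4)c3)c(=O)[nH]2)cc1`: 3040 nM

Of the compounds shown here, two have been measured in a functional assay on UACC-257 cells (Homo sapiens) for inhibition; a higher number here means a weaker inhibitor of growth, a lower number a stronger inhibitor of growth. Compound 1 gives 8690 nM in this assay, and compound 2 gives 3040 nM in this assay. Compound 1 therefore has the higher of the two numbers, and the gap to compound 2 lies beyond the scatter. Compound 3 `COc1ccc(-c2cn(-c3cccc(C(=O)/C=C/c4ccc(O)c(OC)c4)c3)c(=O)[nH]2)cc1` has not yet been measured in this assay. It differs from compound 1 in one place: methoxy in place of chloro on an aromatic carbon. Going by the values given here, compound 2 also carries a 4-methoxyphenyl group, but it differs from compound 1 elsewhere as well, so no measured pair isolates this single change. The expectation for this change is a modest move toward a lower number, a 1.7-fold lower number from compound 1 to compound 3 (0.24 log units; within the scatter), though a result within the scatter would not surprise. Compound 3 is expected to give about 5000 nM in this assay, within a range from 2000 nM to 13000 nM.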

Compound 3, concentration for 50% growth inhibition: 13300 nM
For compound 3 the middle estimate is 2.7-fold (0.42 log units) below the measured one, and the stated range ends below it.
By their numbers in this assay, from the lowest: compound 2; then compounds 1 and 3 (each within the scatter of the next).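

In this assay, replacing 4-chlorophenyl with 4-methoxyphenyl while the 4-hydroxy-3-methoxyphenyl group stays fixed gives a 1.5-fold higher number from compound 1 to compound 3 (0.18 log units; within the scatter), so this pair shows no clear effect of the change at this position. With 4-methoxyphenyl held fixed, replacing 3,4,5-trimethoxyphenyl with 4-hydroxy-3-methoxyphenyl on the double-bonded chain carbon gives a 4.4-fold higher number from compound 2 to compound 3 (0.64 log units; beyond the scatter), so among these three compounds only the change in that group moves the number beyond the scatter. Nothing shown gives a reason for either step.

As far as these compounds go, whether an amine or a carboxylic acid in place of chloro or methoxy would also leave the number within the scatter remains open. So does whether the chloro-to-methoxy swap would give a similar result alongside the 3,4,5-trimethoxyphenyl group.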